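The source may report more compounds than this note shows. Statements on the series, on what has been measured and on what is new or still open speak of the compounds shown alone.

Compound 1, `Nc1ccccc1NC(=O)c1ccc(CSC(=S)N2CCN(c3cccnc3)CC2)cc1`, gives 27.6% in a functional assay on MGC-803 cells (Homo sapiens) for antiproliferative activity, read by CCK-8 assay, with a stated time of 72 h, tested at 2 uM; a higher number here means a stronger effect of the compound at the concentration tested, a lower number a weaker effect.
Compound 2, `COc1ccc(N2CCN(C(=S)SCc3ccc(C(=O)Nc4ccccc4N)cc3)CC2)cc1`, gives 25.3% in this assay.
Compound 3, `N#Cc1ccc(N2CCN(C(=S)SCc3ccc(C(=O)Nc4ccccc4N)cc3)CC2)cc1`, gives 34.5% in this assay.

All three compounds share the same core and differ only in the group attached to an amine nitrogen in a ring. Compound 3 has the highest of the three numbers, but the gaps are small: a number 6.9 percentage points higher from compound 1 to compound 3 (within the scatter) and a number 9.2 percentage points higher from compound 2 to compound 3 (within the scatter), and likewise a number 2.3 percentage points lower from compound 1 to compound 2 (within the scatter). None of these steps is beyond the usual scatter, so the three compounds cannot be ranked against each other on these numbers.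

Compound 4, `Nc1ccccc1NC(=O)c1ccc(CSC(=S)N2CCN(Cc3cccnc3)CC2)cc1`, is not yet measured in this assay. It differs from compound 3 in one place: (pyridin-3-yl)methyl in place of 4-cyanophenyl on an amine nitrogen in a ring. The measured steps that bear on this are the three exchanges of the group on that ring nitrogen, each of which stayed within the scatter, including the change from a pyridin-3-yl group to the 4-cyanophenyl group, a number 6.9 percentage points higher from compound 1 to compound 3 (within the scatter). For the measured compounds named here, no measured step covers the extra methylene that links the pyridine ring to the nitrogen in compound 4, so nothing points to a shift beyond the scatter.

On this basis, the step of a number 6.5 percentage points lower from compound 3 to compound 4 (within the scatter) is expected to stay within the scatter. Compound 4 is therefore estimated to give 28% in this assay, with a likely range from 15% to 42%.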

Compound 4, a percentage reported as inhibition, at one concentration (the size of the read-out at that concentration, not a potency): 37.7%
Compound 4: middle estimate off by 9.7 percentage points, on the low side; low and high end bracket the measured number.
By their numbers in this assay, from the lowest: compounds 2, 1, 3 and 4 (each within the scatter of the next, the first and the last beyond it).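

In this assay, the group on the ring nitrogen now gives its first steps beyond the scatter: (pyridin-3-yl)methyl in place of pyridin-3-yl gives a number 10.1 percentage points higher from compound 1 to compound 4 (beyond the scatter) and, in place of 4-methoxyphenyl, it gives a number 12.4 percentage points higher from compound 2 to compound 4 (beyond the scatter) while every exchange among the three earlier groups stayed within the scatter. So this position does respond to the group placed on it, though only modestly, and the response is no simple gain for (pyridin-3-yl)methyl over every other group: in place of 4-cyanophenyl it gives a number 3.2 percentage points higher from compound 3 to compound 4 (within the scatter) so these two groups cannot be told apart. No measurement shown explains these differences.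

The compounds shown leave open whether a benzyl group, which keeps the methylene link but has a ring of carbon only, or a longer 2-(pyridin-3-yl)ethyl chain would match (pyridin-3-yl)methyl. They also leave open how a small group with no ring, such as methyl or acetyl, would compare on this nitrogen, and these single-concentration read-outs give no potency for any of the compounds.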